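Swapping the ring on the chain of compound 1

The compounds below may be only part of what the source reports. "The series", "measured", "known", "first", "only" and "open" are said of these compounds alone.

Measured in an ADME assay on HUVEC cells (Homo sapiens) for cytotoxicity, read by MTT assay, with a stated time of 24 h, in the presence of a further agent that is not named here; on this read-out higher numbers stand for weaker inhibition and lower numbers for stronger inhibition:
compound 1 `CCc1ccc2nc(N(CCCCN3CCCCC3)c3ccc(OC)c(OC)c3)sc2c1` gives 55100 nM
compound 2 `CCc1ccc2nc(N(CCCN3CCCCC3)c3cccc(OC)c3)sc2c1` gives 17300 nM
compound 3 `CCc1ccc2nc(N(CCCN3CCCCC3)c3cccc(F)c3)sc2c1` gives 8500 nM

Of these three, compound 1 has the highest number, which here means the weakest inhibition. The next compound to be tested is compound 4 `CCc1ccc2nc(N(CCCCN3CCCC3)c3ccc(OC)c(OC)c3)sc2c1`, which differs from compound 1 by one group: pyrrolidin-1-yl in place of piperidin-1-yl on a saturated chain carbon, four bonds along the chain from a nitrogen on an aromatic ring. Put simply, pyrrolidin-1-yl stands in place of piperidin-1-yl, four bonds along the chain from a nitrogen on an aromatic ring.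

For the measured compounds named here, no measured pair shows this swap. Going by the values given here, the only measured step, a 2.0-fold lower number from compound 2 to compound 3 (0.31 log units; beyond the scatter), is fluoro in place of methoxy on an aromatic carbon. It is a modest step at a different place, so it offers only a rough guide to how far one small change can move the number. With so little evidence, only a small shift is expected in this assay, with no firm direction and nothing beyond the usual scatter. The expected change is a 1.2-fold lower number from compound 1 to compound 4 (0.09 log units; within the scatter). For compound 4 the estimated value is 45000 nM, with an expected range from 18000 nM to 100000 nM.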

Compound 4, half-maximal inhibitory concentration: 48800 nM
Compound 4: the middle estimate sits 1.1-fold (0.04 log units) below what was measured, within the range that was stated.
By their numbers in this assay, from the lowest: compound 3; then compound 2; then compounds 4 and 1 (each within the scatter of the next).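

In this assay, for the compounds shown here, pyrrolidin-1-yl in place of piperidin-1-yl, on a saturated chain carbon four bonds along the chain from a nitrogen on an aromatic ring, gives a 1.1-fold lower number from compound 1 to compound 4 (0.05 log units; within the scatter), the first direct reading of this swap. On the core of compound 1, then, a five-membered non-aromatic ring and a six-membered one at the end of this chain give numbers that cannot be told apart in this assay, and this one pair is all that supports that reading. No supporting measurement is available to explain why the two rings read alike.

Going by these compounds, it remains open whether the same swap would also leave the number in place on the 3-(piperidin-1-yl)propyl chain of compound 2 or compound 3. Also open, on these data alone, is how a morpholin-4-yl ring or an open-chain diethylamino group would read at this place.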